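The compounds below may be only part of what the source reports. "The series", "measured", "known", "first", "only" and "open" are said of these compounds alone.

Working notes on the series. In an ADME assay on BaF3 cells (Mus musculus) for antiproliferative activity, read by CCK-8 assay, with a stated time of 72 h (a higher number here means a weaker inhibitor of growth, a lower number a stronger inhibitor of growth), compound 1 `COc1ccc(NC(=O)CCSc2ccc3c(/C=C/c4ccccn4)n[nH]c3c2)cc1C(F)(F)F` reads > 10000 nM, which is a limit of the assay and not a number. Compound 2 `O=C(NCCSc1ccc2c(/C=C/c3ccccn3)n[nH]c2c1)c1cccc(C(F)(F)F)c1` holds the lower of the two actual numbers at 1500 nM, while compound 3 `CN1CCN(Cc2ccc(C(=O)NCCSc3ccc4c(/C=C/c5ccccn5)n[nH]c4c3)cc2C(F)(F)F)CC1` gives 4800 nM. Compound 4 `O=C(NCCSc1ccc2c(/C=C/c3ccccn3)n[nH]c2c1)Nc1cccc(C(F)(F)F)c1` has (3-(trifluoromethyl)phenyl)amino in place of 3-(trifluoromethyl)phenyl on a carbonyl carbon. Going by the values given here, only one measured step bears on this, and only loosely, as it is a different change: a 3.2-fold higher number from compound 2 to compound 3 (0.51 log units; beyond the scatter), a modest rise. A modest step of similar size towards a higher number is therefore expected in this assay, namely a 2.1-fold higher number from compound 2 to compound 4 (0.33 log units; beyond the scatter). For compound 4 the estimated value is 3200 nM, with an expected range of 1000 nM to 9500 nM.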

Compound 4, concentration for 50% growth inhibition: 3000 nM
Estimate against measurement, compound 4: 1.1-fold (0.03 log units) above, and the stated range covers the measured number.
By their numbers in this assay, from the lowest: compounds 2, 4 and 3 (each within the scatter of the next, the first and the last beyond it). At a limit, above all of these: compound 1.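

In this assay, (3-(trifluoromethyl)phenyl)amino in place of 3-(trifluoromethyl)phenyl on a carbonyl carbon gives a 2.0-fold higher number from compound 2 to compound 4 (0.30 log units; within the scatter), so the added nitrogen, with its hydrogen-bond donor, is tolerated at this position. Going by these compounds alone, the earlier step changed the aromatic ring, whereas this is the first reading of a change at the carbonyl carbon itself. Nothing measured here points to a cause for this result. Still open, on these data alone, is whether an ether oxygen or a methylene group in that same place reads alike, and whether a longer chain does.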